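Diethyl amide to pyrrolidine amide on the shared core

A few compounds are considered here, and "the series" means these few. Any claim that something is new, unique, unknown or untested is made for them only; others in the source may bear on it.

Two numbers stand so far in a functional assay on SMMC-7721 cells (Homo sapiens) for antiproliferative activity, read by MTT assay, with a stated time of 48 h (on this read-out higher numbers stand for weaker inhibition and lower numbers for stronger inhibition), for this series. There compound 1 (`CC(C)=CCC[C@]1(C)/C=C/[C@@H](OC(=O)C=C(C)C)[C@](C)(O)/C=C/C(=O)/C(CN(C)C)=C\C1`) gives 820 nM and compound 2 (`CCN(CC)C(=O)/C1=C/C[C@](C)(CCC=C(C)C)/C=C/[C@@H](OC(=O)C=C(C)C)[C@](C)(O)/C=C/C1=O`) gives 13800 nM as the higher of the two. Compound 3 (`CC(C)=CCC[C@]1(C)/C=C/[C@@H](OC(=O)C=C(C)C)[C@](C)(O)/C=C/C(=O)/C(C(=O)N2CCCC2)=C\C1`) departs from compound 2 by one exchange (pyrrolidin-1-yl in place of diethylamino on a carbonyl carbon), pyrrolidin-1-yl in place of diethylamino on a carbonyl carbon. Among the compounds with values here, the only measured step (a 17-fold higher number from compound 1 to compound 2 (1.23 log units; beyond the scatter)) is large and beyond the scatter, but it puts diethylcarbamoyl in place of (dimethylamino)methyl on a double-bonded ring carbon. The carbonyl stays in the present exchange, so that step sets no direct size for it. On these data alone, no step beyond the scatter is expected in this assay and the direction stays open. The estimated step (a 1.3-fold lower number from compound 2 to compound 3 (0.10 log units; within the scatter)) is therefore small. Compound 3 is estimated at 11000 nM with an expected range from 5000 nM to 24000 nM in this read-out.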

Compound 3, half-maximal inhibitory concentration: 14900 nM
Compound 3: middle estimate off by 1.4-fold (0.13 log units), on the low side; low and high end bracket the measured number.
By their numbers in this assay, from the lowest: compound 1; then compounds 2 and 3 (each within the scatter of the next).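

In this assay, pyrrolidin-1-yl in place of diethylamino on a carbonyl carbon gives a 1.1-fold higher number from compound 2 to compound 3 (0.03 log units; within the scatter), which lies within the scatter: at equal heavy-atom count, the ring in the amide gives no readable change in this series. Compound 3 also gives an 18-fold higher number from compound 1 to compound 3 (1.26 log units; beyond the scatter), so the large step away from the (dimethylamino)methyl compound is now seen with two amides, not with diethylcarbamoyl alone. Nothing available explains why the two amides read alike or why both differ from compound 1.

Still open, on these data alone, is whether a (pyrrolidin-1-yl)methyl or (diethylamino)methyl group on the double-bonded ring carbon would stay close to compound 1. A carboxylic acid or an unsubstituted primary amide at that carbon is also untested in the compounds shown here.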